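The source may report more compounds than this note shows. Statements on the series, on what has been measured and on what is new or still open speak of the compounds shown alone.

Measured in a functional assay on CHO-K1 cells for agonist activity at adenosine receptor A1 (Homo sapiens), read by GTPgammaS binding; on this read-out higher numbers stand for an effect only at larger amounts of compound and lower numbers for an effect already at smaller amounts:
compound 1 `CCOC(=O)c1c(-c2cccc(C(F)(F)F)c2)csc1N`: 9.4 uM
compound 2 `CC(=O)c1ccc(-c2sc(N)c(C(=O)c3ccccc3)c2-c2cccc(C(F)(F)F)c2)cc1`: a limit of the assay, > 10 uM
compound 3 `CCOC(=O)c1c(N)sc(-c2cccc(C(C)=O)c2)c1-c1cccc(C(F)(F)F)c1`: a limit of the assay, > 10 uM

Going by the values given here, compound 3 stands at the limit of this assay, so no number is known for it; the only measured step, an at least 1.0-fold higher number from compound 1 to compound 3 (0.02 log units; that floor lies within the scatter), gives just a floor. The change to compound 4 `CCOC(=O)c1c(N)sc(-c2ccc(C(C)=O)cc2)c1-c1cccc(C(F)(F)F)c1` is 4-acetylphenyl in place of 3-acetylphenyl on an aromatic carbon. Among the compounds with values here, no measured step concerns moving the acetyl from one ring position to the other, and the limit of > 10 uM in this assay, at which 2 of the 3 values shown sit, shows where most values in this assay sit. Compound 4 is therefore expected to remain near the limit, with the step that the limit leaves unreadable from compound 3 to compound 4 not beyond the scatter. The estimate for compound 4 is 15 uM, between 5 uM and 45 uM.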

Compound 4, concentration for half-maximal effect: > 10 uM
Compound 4 gave a limit, no number; the forecaster's own chance of this, stated with the estimate: 70%; the middle value does not contradict the limit.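

In this assay, 4-acetylphenyl on this carbon next to the ring sulfur leaves compound 4 at a limit of the assay, as 3-acetylphenyl does for compound 3, so neither placing of the acetyl yields a number. Going by these compounds alone, the steps to compound 4 from compound 3 and from compound 2 cannot be read, and the one readable step is an at least 1.0-fold higher number from compound 1 to compound 4 (0.02 log units; that floor lies within the scatter), a floor only. The series stays crowded at one value: the limit of > 10 uM in this assay, at which 3 of the 4 values shown sit.

From the compounds shown here alone, whether the acetyl position matters at all remains open. Also open, going by these compounds, is whether an amine or a carboxylic acid in place of the acetyl would give a measurable value at this position.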